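The source may report more compounds than this note shows. Statements on the series, on what has been measured and on what is new or still open speak of the compounds shown alone.

In a functional assay on MGC-803 cells (Homo sapiens) for antiproliferative activity, read by CellTiter-Glo, with a stated time of 72 h (on this read-out higher numbers stand for weaker inhibition and lower numbers for stronger inhibition), compound 1 (`O=C(NO)c1ccc(/C=C/c2ccnc(-c3cccc(O)c3)c2)cc1`) gives 2100 nM and compound 2 (`O=C(NO)c1ccc(/C=C/c2ccnc(-c3cccc(CO)c3)c2)cc1`) gives 1740 nM while compound 3 (`Cc1ccc(-c2cc(/C=C/c3ccc(C(=O)NO)cc3)ccn2)cc1`) gives 1910 nM on the same read-out, so compound 3 stands level with the other two, all three values lying within the scatter of one another.

The next structure is compound 4 (`O=C(NO)c1ccc(/C=C/c2ccncc2)cc1`), which differs from compound 3 by hydrogen in place of 4-methylphenyl on an aromatic carbon, so the whole carbon ring leaves.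

Among the compounds with values here, three measured steps bear on this, and only indirectly. They are a 1.2-fold lower number from compound 1 to compound 2 (0.08 log units; within the scatter) and a 1.1-fold lower number from compound 1 to compound 3 (0.04 log units; within the scatter) and a 1.1-fold higher number from compound 2 to compound 3 (0.04 log units; within the scatter) in this series, and all stay within the scatter. Within the data shown here, each of them keeps a ring at that carbon, and no measured compound lacks it, so the size of the coming step is poorly constrained.

The central expectation is a small move towards a higher number, with no step beyond the scatter, and the estimated step is a 1.3-fold higher number from compound 3 to compound 4 (0.12 log units; within the scatter) with wide uncertainty on either side.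

For compound 4 the expected value is 2500 nM with an estimated range from 900 nM to 7000 nM as the working figure.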

Compound 4, half-maximal inhibitory concentration: 3930 nM
Compound 4: the middle estimate sits 1.6-fold (0.20 log units) below what was measured; the range from low to high includes it.
By their numbers in this assay, from the lowest: compounds 2, 3, 1 and 4 (each within the scatter of the next, the first and the last beyond it).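

In this assay, within the data shown here, the carbon next to the ring nitrogen can now be compared with and without an aromatic ring, and for the first time a change there moves the number beyond the scatter: removing 4-methylphenyl gives a 2.1-fold higher number from compound 3 to compound 4 (0.31 log units; beyond the scatter), and removing 3-(hydroxymethyl)phenyl gives a 2.3-fold higher number from compound 2 to compound 4 (0.35 log units; beyond the scatter). Compound 1 goes against a uniform ring effect, since removing 3-hydroxyphenyl gives a 1.9-fold higher number from compound 1 to compound 4 (0.27 log units; within the scatter), so the loss of the ring is modest and is not resolved from the scatter for all three rings. Compound 4 still gives 3930 nM with hydrogen at this carbon, so the ring is not needed for a measurable read-out in this assay, though it is linked to a modest gain in two of the three comparisons.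

The data at hand offer nothing that explains this shift. Going by these compounds, it remains open whether a small group at this carbon, such as methyl or an amine, or a ring carrying a carboxylic acid, would fall with the three ring-bearing compounds or with compound 4.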